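Aryl variation on the triazole nitrogen of the urea series

The compounds below may be only part of what the source reports. "The series", "measured", "known", "first", "only" and "open" are said of these compounds alone.

Measured compounds:
compound 1 `N#Cc1ccc(-n2cc(COc3cccc(NC(=O)Nc4ccc(Cl)c(C(F)(F)F)c4)c3)nn2)cc1` — 2980 nM
compound 2 `CCc1ccc(-n2cc(COc3cccc(NC(=O)Nc4ccc(Cl)c(C(F)(F)F)c4)c3)nn2)cc1` — 1950 nM
compound 3 `O=C(Nc1cccc(OCc2cn(-c3cccc(Br)c3)nn2)c1)Nc1ccc(Cl)c(C(F)(F)F)c1` — 1040 nM

All three were read in a functional assay on HepG2 cells (Homo sapiens) for inhibition, read by MTT assay, with a stated time of 72 h; a lower number here means a stronger inhibitor, a higher number a weaker inhibitor. Compound 1 stands at the highest number of the three. Its nearest neighbour is compound 2, with a 1.5-fold lower number from compound 1 to compound 2 (0.18 log units; within the scatter); the furthest is compound 3, with a 2.9-fold lower number from compound 1 to compound 3 (0.46 log units; beyond the scatter). Between the two other compounds the gap is a 1.9-fold lower number from compound 2 to compound 3 (0.27 log units; within the scatter).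

Compound 4 `COc1ccccc1-n1cc(COc2cccc(NC(=O)Nc3ccc(Cl)c(C(F)(F)F)c3)c2)nn1` is the next member. Relative to compound 1 the change is 2-methoxyphenyl in place of 4-cyanophenyl on an aromatic nitrogen.

Both measured steps from compound 1 touch the same position: the aromatic nitrogen of the five-membered ring carrying an aryl group. Exchanging the substituent on that aryl ring (compound 2) stayed within the scatter, while moving to a 3-bromophenyl (compound 3) gave a modest lowering beyond it. Going by the values given here, no measured compound carries a 2-methoxyphenyl or any other group at that place on the aryl ring, so the direction rests on the two steps alone. A small lowering from compound 1, likely no larger than the scatter, is expected for compound 4: a 1.5-fold lower number from compound 1 to compound 4 (0.17 log units; within the scatter). The estimated value for compound 4 in this assay is 2000 nM, with a range from 900 nM to 4500 nM.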

Compound 4, half-maximal inhibitory concentration: 11300 nM
For compound 4 the middle estimate is 5.7-fold (0.75 log units) below the measured one; the whole stated range lies below it.
By their numbers in this assay, from the lowest: compounds 3, 2 and 1 (each within the scatter of the next, the first and the last beyond it); then compound 4.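

In this assay, going by these compounds alone, the 2-methoxyphenyl group of compound 4 is the first aryl group on this aromatic nitrogen to raise the number, with all three new steps beyond the scatter (a 3.8-fold higher number from compound 1 to compound 4 (0.58 log units; beyond the scatter); a 5.8-fold higher number from compound 2 to compound 4 (0.76 log units; beyond the scatter); an 11-fold higher number from compound 3 to compound 4 (1.04 log units; beyond the scatter)). Within the data shown here, the position is therefore more sensitive to the choice of aryl group than the earlier compounds showed, since their widest gap was modest (a 2.9-fold lower number from compound 1 to compound 3 (0.46 log units; beyond the scatter)), while the gap now opened to the 3-bromophenyl of compound 3 is large. No supporting data bear on why the 2-methoxyphenyl group stands apart from the other three aryl groups.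

The step from compound 1 to compound 4 changes both the substituent and its place on the aryl ring, so these two contributions cannot be separated with the compounds shown. A 4-methoxyphenyl or 3-methoxyphenyl group would help to separate them, and an unsubstituted phenyl group would give a common reference for all four aryl groups.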